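Chain extension by hexyl at the amide end of the series

The source may hold more compounds than are shown below. What is called first, only, known or untested is meant among the compounds shown, and "the series" means these compounds.

Among the compounds with values here, compound 1 `CCCCCCCCCCCCNC(=O)[C@@H](NC(=O)c1nccc2ccccc12)[C@@H](C)O` is the only member of the set with a number in a functional assay on HepG2 cells (Homo sapiens) for cytotoxicity, read by MTT assay, with a stated time of 48 h; a lower number here means a stronger inhibitor, a higher number a weaker inhibitor: compound 1 gives 65700 nM. Compound 2 `CCCCCCCCCCCCNC(=O)[C@@H](NC(=O)/C=C/c1ccccc1)[C@@H](C)O` carries a 2-phenylethenyl group in place of the isoquinolin-1-yl group on the carbonyl carbon; in this assay compound 2 reaches only the limit of the assay, > 200000 nM, and no number. That step, an at least 3.0-fold higher number from compound 1 to compound 2 (0.48 log units; beyond the scatter), rests on (the limit of > 200000 nM in this assay, at which 1 of the 2 values shown sits).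

Compound 3 `CCCCCCCCCCCCCCCCCCNC(=O)[C@@H](NC(=O)c1nccc2ccccc12)[C@@H](C)O` differs from compound 1 at the far end of the saturated chain: hexyl in place of hydrogen on a saturated chain carbon, ten or more bonds along the chain from an amide-type nitrogen. Within the data shown here, the single measured step concerns the group on the carbonyl carbon and says nothing about the length of the chain, so no measured step bears on the change from compound 1 to compound 3. With no chain-length step shown, no direction can be taken from the data; the working expectation is a step within the scatter in this assay, no change at the digits printed from compound 1 to compound 3 (within the scatter). Compound 3 is therefore expected at about 65700 nM in this assay, within a range from 22000 nM to 200000 nM.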

Compound 3, half-maximal inhibitory concentration: 96900 nM
For compound 3 the middle estimate is 1.5-fold (0.17 log units) below the measured one; the range from low to high includes it.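

In this assay, the chain gets its first measured step, a 1.5-fold higher number from compound 1 to compound 3 (0.17 log units; within the scatter). The earlier step concerned only the group on the carbonyl carbon; this one shows that hexyl in place of hydrogen on a saturated chain carbon, ten or more bonds along the chain from an amide-type nitrogen, leaves compound 3 not distinguishable from compound 1, and compound 3 carries a measured number rather than a limit of the assay. Nothing in the data on hand speaks to a cause for this step.

With only these two chain lengths shown, a shorter chain, a still longer chain, or a chain ending in an amine or a carboxylic acid remains an open question at this position. Also open is whether the same hexyl change gives a step within the scatter when 2-phenylethenyl sits on the carbonyl carbon, and compound 2, the one compound shown with that group, stands at a limit of the assay.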